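This account rests on a few compounds, and the source may have more. Where it says the series, first, only, none or still open, it means among the compounds named here.

The series shares the core of compound 2 `Cc1oc(-c2ccc(Cl)c(Cl)c2)nc1CN1CCC(C(=O)NCCCN2C[C@H](C)C[C@H](C)C2)CC1`; compound 1 `Cc1ccccc1-c1nc(CN2CCC(C(=O)NCCCN3CC(C)(C)CC(C)(C)C3)CC2)c(C)o1`, compound 3 `Cc1cccc(Cl)c1-c1nc(CN2CCC(C(=O)NCCCN3CCC(C(C)C)CC3)CC2)c(C)o1` and compound 4 `COc1cccc(C)c1-c1nc(CN2CCC(C(=O)NCCCN3C[C@H](C)C[C@H](C)C3)CC2)c(C)o1` differ from it only in the group on the five-membered aromatic ring. Within the data shown here, in a physicochemical assay for permeability, using PAMPA (a higher number here means that the compound crosses the layer faster, a lower number that the compound crosses the layer more slowly), compound 2 gives 522 10^-6 cm/s, the only plain number in the set. For compound 1 this assay reports only a limit, > 1390 10^-6 cm/s. For compound 3 the result in this assay is "not determined" (no result reported). Among the measured compounds shown here, compound 2 therefore stands as the sole fixed number against which compound 4 can be set. The change is 2-methoxy-6-methylphenyl in place of 3,4-dichlorophenyl on an aromatic carbon. For the measured compounds named here, no measured step between two compounds exists, so the expected step rests on structure alone. Given compound 1 at the limit of > 1390 10^-6 cm/s in this assay, at which 1 of the 3 values shown sits, a shift upward or none beyond the scatter is expected. Compound 4 is estimated at 650 10^-6 cm/s, within 280 10^-6 cm/s to 1390 10^-6 cm/s, meaning an expected step of a 1.2-fold higher number from compound 2 to compound 4 (0.10 log units; within the scatter).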

Compound 4, apparent permeability: 198 10^-6 cm/s
The estimate for compound 4 lay 3.3-fold (0.52 log units) above the measured number, and the stated range ends above it.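

In this assay, among these compounds, swapping the group on this aromatic carbon, next to the ring nitrogen and the ring oxygen, gives a 2.6-fold lower number from compound 2 to compound 4 (0.42 log units; beyond the scatter) and is the first measured step at this position. The position therefore responds to the group it carries, and the response here is downward. Among the compounds shown here, an upward move has no number behind it, as the only other reading with an aryl change is a limit: the limit of > 1390 10^-6 cm/s in this assay, at which 1 of the 4 values shown sits.

Going by these compounds, whether the methoxy, the methyl or their placement on the phenyl carries the step stays open. So does the outcome for an unsubstituted phenyl or a phenyl bearing a carboxylic acid.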